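Sulfonyl-pyrimidinone series: benzyl to aryl sulfone step

This account rests on a few compounds, and the source may have more. Where it says the series, first, only, none or still open, it means among the compounds named here.

Three compounds of the series have numbers in a functional assay on DU-145 cells (Homo sapiens) for inhibition, read by trypan blue exclusion, with a stated time of 72 h; a lower number here means a stronger inhibitor, a higher number a weaker inhibitor. Compound 1 `Cn1c(=O)c(S(=O)(=O)c2ccc(F)cc2)cc2cnc(Nc3cccc4[nH]ccc34)nc21` gives 750 nM. Compound 2 `Cn1c(=O)c(S(=O)(=O)Cc2ccc(F)cc2F)cc2cnc(Nc3ccc4[nH]ccc4c3)nc21` gives 1000 nM in this assay. Compound 3 `Cn1c(=O)c(S(=O)(=O)c2ccc(F)cc2F)cc2cnc(Nc3ccc4[nH]c(C(=O)O)cc4c3)nc21` gives 10000 nM in this assay. Compound 2 thus holds the second highest of the three numbers; its number and that of compound 1 lie within the usual scatter of each other, so no order between them is claimed, while compound 3 sits beyond the scatter with a clearly higher number. No pair among these three differs in only one place, so no single step can be read off the measured set.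

Compound 4 `Cn1c(=O)c(S(=O)(=O)c2ccc([N+](=O)[O-])cc2F)cc2cnc(Nc3ccc4[nH]ccc4c3)nc21` is not yet measured. Against compound 2 the change is 2-fluoro-4-nitrophenyl in place of 2,4-difluorobenzyl on a sulfonyl sulfur. Compound 1 and compound 3 both carry an aryl group directly on the sulfonyl sulfur, as compound 4 does, yet they differ from compound 2 elsewhere as well, so they give no clean guide.

With nothing firmer to rest on, the step from compound 2 to compound 4 in this assay is expected to be small, a 1.3-fold lower number from compound 2 to compound 4 (0.10 log units; within the scatter), not clearly beyond the scatter in either direction. Compound 4 is therefore estimated at 800 nM, with a range from 250 nM to 2500 nM.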

Compound 4, half-maximal inhibitory concentration: 400 nM
Beside the measured number, compound 4's estimate is 2.0-fold (0.30 log units) above it; measured number inside the range.
By their numbers in this assay, from the lowest: compounds 4, 1 and 2 (each within the scatter of the next, the first and the last beyond it); then compound 3.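

In this assay, the series now has its first step that can be read at a single place: a 2.5-fold lower number from compound 2 to compound 4 (0.40 log units; beyond the scatter), with 2-fluoro-4-nitrophenyl in place of 2,4-difluorobenzyl on a sulfonyl sulfur. The step is modest, but it shows that this place accepts a substantial change of group, from a benzyl to a phenyl carrying a nitro group, without a higher number in this assay. The change is compound in itself, since the benzyl carbon leaves and a nitro group replaces one fluorine in the same step, and no measurement here explains the lower number.

Which of these two differences accounts for the step stays open, and a 2,4-difluorophenyl group or a 2-fluoro-4-nitrobenzyl group on the same sulfonyl sulfur, with the rest of compound 4 unchanged, would separate them. Also open, from the compounds shown here alone, is whether the nitro group itself matters, which an amine, a nitrile or a carboxylic acid in its place on the phenyl ring would test.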